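Swapping the Benzothiazole for a Methyltriazole on Sulfur

The source may hold more compounds than are shown below. What is called first, only, known or untested is meant among the compounds shown, and "the series" means these compounds.

Measured in a functional assay on MCF7 cells (Homo sapiens) for cytotoxicity, read by MTT assay, with a stated time of 24 h; a higher number here means a weaker inhibitor, a lower number a stronger inhibitor:
Compound 1, `Cn1c(-c2ccc(NC(=O)CCl)cc2)nc(-c2ccccc2)c1-c1ccccc1`, gives 42.6 ug/mL.
Compound 2, `Cn1c(-c2ccc(NC(=O)CSc3nc4ccccc4o3)cc2)nc(-c2ccccc2)c1-c1ccccc1`, gives 11.2 ug/mL.
Compound 3, `Cn1c(-c2ccc(NC(=O)CSc3nc4ccccc4s3)cc2)nc(-c2ccccc2)c1-c1ccccc1`, gives 15.8 ug/mL.

Compound 3 stands second highest of the three numbers, within the scatter of compound 2 and beyond it from compound 1, as a 2.7-fold lower number from compound 1 to compound 3 (0.43 log units; beyond the scatter) shows. Compound 4, `Cn1cnnc1SCC(=O)Nc1ccc(-c2nc(-c3ccccc3)c(-c3ccccc3)n2C)cc1`, differs from compound 3 by 4-methyl-4H-1,2,4-triazol-3-yl in place of 1,3-benzothiazol-2-yl on a sulfur. Among the measured compounds shown here, no measured step covers this change directly. The nearest guides are a 3.8-fold lower number from compound 1 to compound 2 (0.58 log units; beyond the scatter) and a 2.7-fold lower number from compound 1 to compound 3 (0.43 log units; beyond the scatter), both modest, and a 1.4-fold higher number from compound 2 to compound 3 (0.15 log units; within the scatter), which shows that exchanging one ring on the sulfur for another changed little. Going by these compounds, a single five-membered ring here is untested, so a step within the scatter, or a modest move back toward compound 1, seems most likely. The expected step is a 1.3-fold higher number from compound 3 to compound 4 (0.10 log units; within the scatter). Compound 4 is expected to give 20 ug/mL, within a range from 8 ug/mL to 50 ug/mL.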

Compound 4, half-maximal inhibitory concentration: 3.2 ug/mL
Compound 4: the middle estimate sits 6.3-fold (0.80 log units) above what was measured, and the stated range ends above it.
By their numbers in this assay, from the lowest: compound 4; then compounds 2 and 3 (each within the scatter of the next); then compound 1.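

The group on the sulfur matters more in this assay than the two fused-ring groups suggested, since 4-methyl-4H-1,2,4-triazol-3-yl gives a 4.9-fold lower number from compound 3 to compound 4 (0.69 log units; beyond the scatter) and a 3.5-fold lower number from compound 2 to compound 4 (0.54 log units; beyond the scatter), whereas the exchange between those two fused-ring groups stayed within the scatter. Measured against chloro, the same group gives a 13-fold lower number from compound 1 to compound 4 (1.12 log units; beyond the scatter), a large step where the fused-ring groups gave modest ones. No measurement here explains this difference. Going by these compounds, whether the methyl on the 4-methyl-4H-1,2,4-triazol-3-yl group is needed remains open. So does how an amine or a carboxylic acid would read at this position.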